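This account rests on a few compounds, and the source may have more. Where it says the series, first, only, none or still open, it means among the compounds named here.

In a functional assay on HepG2 cells (Homo sapiens) for antiproliferative activity, read by MTT assay, with a stated time of 24 h (a lower number here means a stronger inhibitor, a higher number a weaker inhibitor), compound 1 (`COC(=O)c1scc(-c2ccc(NC(=O)c3ccc4ccccc4c3)cc2)c1OC`) gives 19500 nM and compound 2 (`COC(=O)c1scc(-c2ccc(NC(=O)c3cccc(C(F)(F)F)c3)cc2)c1OC`) gives 32500 nM as its result. Compound 3 (`COC(=O)c1scc(-c2ccc(NC(=O)c3cc(I)ccc3F)cc2)c1OC`) has no number to stand on, its entry being "not determined" (no result reported) with no result reported. Going to compound 4 (`COC(=O)c1scc(-c2ccc(NC(=O)c3ccc(C(F)(F)F)cc3)cc2)c1OC`) puts 4-(trifluoromethyl)phenyl in place of 2-fluoro-5-iodophenyl on a carbonyl carbon. For the measured compounds named here, no measured step starts from compound 3. Going by the values given here, the one measured step (a 1.7-fold higher number from compound 1 to compound 2 (0.22 log units; within the scatter)) also exchanges the group on a carbonyl carbon and lies within the scatter, so no step beyond the scatter is expected in this assay from such an exchange. With no starting number, the estimate leans on the values of compound 1 and compound 2 alone. For compound 4 the expected value is 25000 nM with an estimated range from 12000 nM to 50000 nM in all.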

Compound 4, half-maximal inhibitory concentration: 24600 nM
Estimate against measurement, compound 4: 1.0-fold (0.01 log units) above, within the range that was stated.
By their numbers in this assay, from the lowest: compounds 1, 4 and 2 (each within the scatter of the next).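

Within this assay the exchange of 3-(trifluoromethyl)phenyl for 4-(trifluoromethyl)phenyl on a carbonyl carbon gives a 1.3-fold lower number from compound 2 to compound 4 (0.12 log units; within the scatter) and the exchange of naphthalen-2-yl for 4-(trifluoromethyl)phenyl gives a 1.3-fold higher number from compound 1 to compound 4 (0.10 log units; within the scatter) at the same place. Shifting the trifluoromethyl group on the phenyl ring therefore brings no change that can be read, and compounds 1, 2 and 4 all stay within the scatter of one another. No evidence is available to explain this result. As far as these compounds go, what stays open is whether an amine or a carboxylic acid on this phenyl ring would give a step beyond the scatter. Compound 3 has no number, so the 2-fluoro-5-iodophenyl group cannot be compared.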